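The source may hold more compounds than are shown below. What is called first, only, known or untested is meant among the compounds shown, and "the series" means these compounds.

In a functional assay on RAW264.7 cells (Mus musculus) for inhibition, read by Griess assay, with stated times of 1 h and 24 h (on this read-out lower numbers stand for stronger inhibition and higher numbers for weaker inhibition), compound 3 (`COc1ccccc1C1CC(=O)c2ccccc2O1`) gives 47300 nM, within the scatter of compound 2 (`CCCCOc1ccccc1C1CC(=O)c2ccccc2O1`) at 48700 nM and of compound 1 (`CCCCCOc1ccccc1C1CC(=O)c2ccccc2O1`) at 39200 nM. Compound 4 (`O=C1CC(c2ccccc2O)Oc2ccccc21`) is the next step: hydrogen in place of methyl on an oxygen on an aromatic ring, methoxy to hydroxy. The measured steps that bear on it alter the chain on that same oxygen: a 1.0-fold lower number from compound 2 to compound 3 (0.01 log units; within the scatter), a 1.2-fold higher number from compound 1 to compound 3 (0.08 log units; within the scatter) and a 1.2-fold higher number from compound 1 to compound 2 (0.09 log units; within the scatter), all within the scatter. Among the measured compounds shown here, none of them removes the chain entirely, and no hydroxy compound has been measured, so the range stays wide. No step beyond the scatter is expected in this assay, and the estimated change is a 1.2-fold lower number from compound 3 to compound 4 (0.07 log units; within the scatter). For compound 4 the estimated value is 40000 nM, expected between 16000 nM and 90000 nM.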

Compound 4, half-maximal inhibitory concentration: 71300 nM
For compound 4 the middle estimate is 1.8-fold (0.25 log units) below the measured one; the range from low to high includes it.
By their numbers in this assay, from the lowest: compounds 1, 3, 2 and 4 (each within the scatter of the next).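

Taking the whole chain off the oxygen on the aromatic ring, which no earlier step did, still stays within the scatter in this assay (a 1.5-fold higher number from compound 3 to compound 4 (0.18 log units; within the scatter); a 1.5-fold higher number from compound 2 to compound 4 (0.17 log units; within the scatter); a 1.8-fold higher number from compound 1 to compound 4 (0.26 log units; within the scatter)). Across hydrogen, methyl, butyl and pentyl on this oxygen, compounds 1 to 4 show no step beyond the scatter. Nothing on hand explains these numbers.

Open, from the compounds shown here alone, is whether a chain longer than pentyl, or a carboxylic acid or an amine carried on that oxygen, would move the number beyond the scatter. Changes elsewhere on the shared core also remain open.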